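Amino Substitution on Chlorinated Purine Benzyl Halides in Hs-578T Cells

The source may hold more compounds than are shown below. What is called first, only, known or untested is meant among the compounds shown, and "the series" means these compounds.

Compound 1 `ClCc1ccc(Cn2cnc3c(Cl)ncnc32)cc1` gives only a limit in this assay, > 100000 nM. Compound 2 `Nc1nc(Cl)c2ncn(Cc3ccc(CCl)cc3)c2n1` likewise gives only a limit, > 100000 nM. Compound 3 `ClCc1ccccc1Cn1cnc2c(Cl)ncnc21` gives 56200 nM.

The three compounds were tested in a functional assay on Hs-578T cells (Homo sapiens) for cytotoxicity, read by sulforhodamine B assay, with a stated time of 48 h; on this read-out higher numbers stand for lower toxicity in this test and lower numbers for higher toxicity in this test. Compound 1 and compound 2 differ by one change, (amino in place of hydrogen on an aromatic carbon), and the step that the two limits leave unreadable from compound 1 to compound 2 cannot be read, because both values sit at the limit of > 100000 nM in this assay, at which 2 of the 3 values shown sit. Compound 3 shares its atoms with compound 1 but joins them differently; the difference between the two cores is not broken down here.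

Compound 4 `Nc1nc(Cl)c2ncn(Cc3ccccc3CCl)c2n1` has not yet been measured. It differs from compound 3 by amino in place of hydrogen on an aromatic carbon, the same change as that from compound 1 to compound 2. Since the earlier step that the two limits leave unreadable from compound 1 to compound 2 gives no readable size, there is no measured basis for a direction, so the expected step of a 1.1-fold higher number from compound 3 to compound 4 (0.03 log units; within the scatter) is set close to no change. Compound 4 is therefore estimated at 60000 nM, with a wide range from 20000 nM to 180000 nM.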

Compound 4, concentration lethal to 50% of the cells: > 100000 nM
Compound 4: a limit, no number (the forecaster's own chance of this, stated with the estimate: 40%); at least 1.6-fold (0.22 log units) between middle value and limit.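

Carrying amino in place of hydrogen on an aromatic carbon onto the core of compound 3 gives an at least 1.7-fold higher number from compound 3 to compound 4 (0.25 log units; that floor lies within the scatter) in this assay. Compound 4 gives only a limit, > 100000 nM, so this step has a floor and no size, and with that floor inside the usual scatter it does not establish a real rise in the number. The same change on the core of compound 1 cannot be read, so the size of the change cannot be compared between the two cores, and the two amino compounds show only that both end at the same limit: the limit of > 100000 nM in this assay, at which 3 of the 4 values shown sit.

The compounds shown leave open whether a group other than amino at this place, such as methoxy or dimethylamino, would give a readable number on either core. They also leave open what a hydroxymethyl group in place of the chloromethyl group would do to the number of compound 3.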